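A few compounds are considered here, and "the series" means these few. Any claim that something is new, unique, unknown or untested is made for them only; others in the source may bear on it.

Compound 1 `CCO/C(O)=C1\C(C)=NC(C)=C([N+](=O)[O-])C1c1ccccn1` belongs to a set of three measured compounds built on the same core, together with compound 2 `COCCO/C(O)=C1\C(C)=NC(C)=C([N+](=O)[O-])C1c1ccccn1` and compound 3 `CC1=NC(C)=C([N+](=O)[O-])C(c2ccccn2)/C1=C(\O)OC1CCCC1`. In a functional assay (cardiac atrium) for agonist activity, with Cavia porcellus as the target (a higher number here means that more compound is needed for the effect, a lower number that less compound is needed), compound 1 gives 22800 nM, compound 2 gives 9700 nM and compound 3 gives 19800 nM. Compound 1 thus has the highest of the three numbers: the nearest is compound 3, the furthest compound 2. The steps among them are a 2.4-fold lower number from compound 1 to compound 2 (0.37 log units; beyond the scatter), a 1.2-fold lower number from compound 1 to compound 3 (0.06 log units; within the scatter) and a 2.0-fold higher number from compound 2 to compound 3 (0.31 log units; beyond the scatter). All three of these steps change only the group on the oxygen on the unsaturated carbon, so none of them touches the part of the molecule that changes on the way to compound 4 `CCO/C(O)=C1\C(C)=NC(C)=C([N+](=O)[O-])C1c1ccncc1`. That change is pyridin-4-yl in place of pyridin-2-yl on a saturated ring carbon. Among the compounds with values here, with no measured step bearing on this position, there is no basis for expecting a shift in either direction, so the expected step is a 1.0-fold lower number from compound 1 to compound 4 (0.02 log units; within the scatter), within the scatter, though with a wide range. Compound 4 is therefore estimated at 22000 nM in this assay, between 5000 nM and 90000 nM.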

Compound 4, half-maximal effective concentration: 6460 nM
Compound 4: the middle estimate sits 3.4-fold (0.53 log units) above what was measured; the measured number falls inside the stated range.
By their numbers in this assay, from the lowest: compounds 4 and 2 (each within the scatter of the next); then compounds 3 and 1 (each within the scatter of the next).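

In this assay, exchanging pyridin-2-yl for pyridin-4-yl on the saturated ring carbon gives a 3.5-fold lower number from compound 1 to compound 4 (0.55 log units; beyond the scatter). Within the data shown here, this is the first measured sign that this position responds to a change, and the swap keeps the same atoms and alters only how they are joined, so the attachment of the pyridine ring alone is enough to shift the number. No measurement available here accounts for the shift.

The compounds shown leave open how pyridin-3-yl, or a phenyl ring with no ring nitrogen, would read at this position. They also leave open whether the same step would appear with 2-methoxyethyl or cyclopentyl on the oxygen, as in compound 2 and compound 3, as it is seen here only with the ethyl group of compound 1.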